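Removing an Ethyl Ester: Expectations for a Free Acid

This account rests on a few compounds, and the source may have more. Where it says the series, first, only, none or still open, it means among the compounds named here.

Measured so far:
compound 1 `Cc1nc(C)c(C(=O)Oc2cccc(/C=C/C(=O)O)c2)nc1C` — 61.6%
compound 2 `CCOC(=O)/C=C/c1cc(OC)c(OC(=O)c2nc(C)c(C)nc2C)c(OC)c1` — 96.6%
compound 3 `Cc1nc(C)c(C(=O)Oc2ccc(/C=C/C(=O)O)cc2)nc1C` — 34.2%

Of the compounds shown here, three share a core and have been tested in a functional assay on EA.hy 926 cells (Homo sapiens) for cytotoxicity, read by MTT assay, with stated times of 24 h and 12 h, tested at 12.5 uM; a lower number here means a weaker effect, a higher number a stronger effect of the compound at the concentration tested. Compound 2 `CCOC(=O)/C=C/c1cc(OC)c(OC(=O)c2nc(C)c(C)nc2C)c(OC)c1` gives the highest number, 96.6%. Its nearest neighbour on the numbers is compound 1, at 61.6%, a gap beyond the scatter; furthest is compound 3, at 34.2%, also well beyond the scatter.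

Compound 4 `COc1cc(/C=C/C(=O)O)cc(OC)c1OC(=O)c1nc(C)c(C)nc1C` has not yet been measured in this assay. It differs from compound 2 in one place: hydrogen in place of ethyl on an oxygen next to a carbonyl group. Read one bond further out, ethoxycarbonyl becomes carboxy.

Within the data shown here, no step between measured compounds shows this change directly. Still, the two measured compounds that carry a carboxy group, compound 1 and compound 3, both give clearly lower numbers than the ethyl ester compound 2. A drop is therefore expected for compound 4 in this assay, with the step from compound 2 to compound 4 estimated at a number 41.6 percentage points lower from compound 2 to compound 4 (beyond the scatter). The estimated value for compound 4 is 55%, within a range of 30% to 85%. The range is wide because compound 1 gives 61.6% and compound 3 gives 34.2%, a spread among the carboxy compounds.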

Compound 4, a percentage reported as activity, at one concentration (the size of the read-out at that concentration, not a potency): 5.7%
Beside the measured number, compound 4's estimate is 49.3 percentage points above it, outside the stated range (below it).
By their numbers in this assay, from the lowest: compound 4; then compound 3; then compound 1; then compound 2.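

In this assay, the change from ethoxycarbonyl to carboxy can now be read directly, with the rest of the structure unchanged: a number 90.9 percentage points lower from compound 2 to compound 4 (beyond the scatter). The earlier compounds shown here could not isolate this swap of ethyl for hydrogen on an oxygen next to a carbonyl group, and it shows that losing just 2 heavy atoms at this place is enough to produce a large step at the concentration tested. Nothing shown here gives a measured reason for a step of this size.

The compounds shown leave open whether the high number of compound 2 is specific to ethyl, since a methyl group or a longer propyl chain on the same oxygen would be needed to tell. They also leave open how an amide would read in place of the ester.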